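The source may report more compounds than this note shows. Statements on the series, on what has been measured and on what is new or still open speak of the compounds shown alone.

Compound 1 `Cc1cc[n+]([O-])cc1Oc1ccccc1`: 30 mg/kg
Compound 2 `Cc1cc(Oc2ccccc2)c[n+]([O-])c1`: 100 mg/kg
Compound 3 `Cc1c(Oc2ccccc2)ccc[n+]1[O-]`: 300 mg/kg

In a functional assay on the whole organism with Mus musculus as the target, in the maximal electroshock model, with a stated time of 30 min (on this read-out lower numbers stand for an effect already at smaller amounts and higher numbers for an effect only at larger amounts of compound), compound 1 gives 30 mg/kg, the lowest of the three numbers. Compound 2 shows a higher number, and compound 3 a higher one still; both gaps lie beyond the scatter. These three differ in where the groups sit on the shared core, so no single-point change among them matches the change now considered.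

Compound 4 `N#Cc1cc[n+]([O-])cc1Oc1ccccc1` differs from compound 1 in this way: cyano in place of methyl on an aromatic carbon. Within the data shown here, no measured pair shows this exchange, so only a modest step is expected in this assay, with its direction open and possibly within the scatter. Compound 4 is therefore estimated at 50 mg/kg, with a range of 15 mg/kg to 150 mg/kg, meaning an expected step of a 1.7-fold higher number from compound 1 to compound 4 (0.22 log units; within the scatter).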

Compound 4, minimum effective dose: 300 mg/kg
Estimate against measurement, compound 4: 6.0-fold (0.78 log units) below; the whole stated range lies below it.
By their numbers in this assay, from the lowest: compound 1; then compound 2; then compounds 3 and 4 (each within the scatter of the next).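

In this assay cyano in place of methyl on this aromatic carbon gives a 10-fold higher number from compound 1 to compound 4 (1.00 log units; beyond the scatter) and so shows that the group at this place matters, not only where the groups sit. The earlier compounds shown here varied only those placements, whereas this pair changes the group itself at one fixed place. Nothing available explains the rise.

From the compounds shown here alone, whether an amine or a methoxy group at this carbon would keep the number near that of compound 1 remains open. So does whether losing methyl or gaining cyano drives the step.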